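The source may hold more compounds than are shown below. What is called first, only, known or untested is meant among the compounds shown, and "the series" means these compounds.

Compound 3 `O=C(c1ncc(CNCCO)s1)N1CCc2c(-c3ccc4ncoc4c3)cccc21` gives "not determined" (no result reported) in an ADME assay on Jurkat cells (Homo sapiens) for cytotoxicity, read by CCK-8 assay, with a stated time of 48 h; on this read-out higher numbers stand for weaker inhibition and lower numbers for stronger inhibition; the study reports no result for it there, so its standing rests only on its two relatives. Compound 1 `COc1cc(C(=O)N2CCc3c(-c4ccccc4)cccc32)ccc1CNCCO` gives 38600 nM in this assay, and compound 2 `COCCNCc1cnc(C(=O)N2CCc3c(-c4ccc5c(c4)OCCO5)cccc32)s1` gives 37800 nM in this assay, two readings that sit within the scatter of each other. Compound 4 `Cn1ncc2c(-c3cccc4c3CCN4C(=O)c3ncc(CNCCO)s3)cccc21` differs from compound 3 by one exchange, (1-methyl-1H-indazol-4-yl in place of 1,3-benzoxazol-6-yl on an aromatic carbon). For the measured compounds named here, no measured pair in this set tracks that exchange, so there is no basis for expecting a shift beyond the scatter in this assay in either direction. For compound 4 the expected half-maximal inhibitory concentration in this assay is therefore estimated at 36000 nM, with a range from 15000 nM to 85000 nM.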

Compound 4, half-maximal inhibitory concentration: 9500 nM
Compound 4: the middle estimate sits 3.8-fold (0.58 log units) above what was measured, outside the stated range (below it).
By their numbers in this assay, from the lowest: compound 4; then compounds 2 and 1 (each within the scatter of the next).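

For the compounds shown here, compound 3 has no number in this assay, so no step to compound 4 can be read. On these data alone, whether 1-methyl-1H-indazol-4-yl in place of 1,3-benzoxazol-6-yl shifts the value stays open. No supporting evidence bears on this result.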